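A few compounds are considered here, and "the series" means these few. Any claim that something is new, unique, unknown or untested is made for them only; others in the source may bear on it.

Compounds measured so far in a functional assay on 786-0 cells (Homo sapiens) for antiproliferative activity, with a stated time of 48 h; on this read-out lower numbers stand for higher toxicity in this test and higher numbers for lower toxicity in this test:

compound 1, `Cc1cc(O)c(C2=NN(c3ccc(S(N)(=O)=O)cc3)C(c3ccccc3Cl)C2)cc1Cl`, gives 9100 nM
compound 2, `Cc1cc(O)c(C2=NN(c3ccc(S(N)(=O)=O)cc3)C(/C=C/c3ccccc3)C2)cc1Cl`, gives 35300 nM

Among these two numbers compound 2 stands highest, and its nearest neighbour is compound 1, the step between them being a 3.9-fold higher number from compound 1 to compound 2 (0.59 log units; beyond the scatter), a change that replaced 2-chlorophenyl by 2-phenylethenyl on a saturated ring carbon.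

Compound 3, `COc1ccc(C2CC(c3cc(Cl)c(C)cc3O)=NN2c2ccc(S(N)(=O)=O)cc2)cc1OC`, is not yet measured. It differs from compound 2 as follows: 3,4-dimethoxyphenyl in place of 2-phenylethenyl on a saturated ring carbon. For the measured compounds named here, the only measured step that bears on this position is a 3.9-fold higher number from compound 1 to compound 2 (0.59 log units; beyond the scatter), which shows that removing an aromatic ring from that saturated ring carbon in favour of 2-phenylethenyl raised the number. Compound 3 puts an aromatic ring back there, although one carrying two methoxy groups that compound 1 does not have, so the size of the return is uncertain.

For compound 3 the number in this assay is expected to be about 13000 nM, in the range 4500 nM to 40000 nM, which means an expected step of a 2.7-fold lower number from compound 2 to compound 3 (0.43 log units; beyond the scatter).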

Compound 3, concentration lethal to 50% of the cells: > 100000 nM
Compound 3: only a limit was reported; the forecaster's own chance of this, stated with the estimate: 10%; at least 7.6-fold (0.88 log units) between middle value and limit.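

In this assay compound 3 gives a limit and not a number: the limit of > 100000 nM in this assay, at which 1 of the 3 values shown sits. Even so, the steps show that an aromatic ring on this saturated ring carbon does not by itself keep the number low: 3,4-dimethoxyphenyl in place of 2-phenylethenyl gives an at least 2.8-fold higher number from compound 2 to compound 3 (0.45 log units; beyond the scatter), and 3,4-dimethoxyphenyl in place of 2-chlorophenyl gives an at least 10-fold higher number from compound 1 to compound 3 (1.04 log units; beyond the scatter). The second step, the larger of the two, sets apart two phenyl rings that differ only in what they carry, so at this position the substituents on the ring count, which the earlier pair could not show.

Going by these compounds, how far compound 3 lies beyond its limit remains unknown, so neither step has an upper end. On these data alone, whether a phenyl ring with a single methoxy group, or one carrying an amine, would behave like 2-chlorophenyl or like 3,4-dimethoxyphenyl also stays open.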